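A Dimethylphenol in Place of a Methoxyphenol

This account rests on a few compounds, and the source may have more. Where it says the series, first, only, none or still open, it means among the compounds named here.

Three compounds sharing one core, compound 1 `CN(C)CCn1cnnc1-c1cc(Oc2ccc(NC(=O)N/N=C/c3ccc(Cl)cc3Cl)cc2F)ccn1`, compound 2 `COc1ccc(/C=N/NC(=O)Nc2ccc(Oc3ccnc(-c4nncn4CCN(C)C)c3)c(F)c2)c(OC)c1OC` and compound 3 `COc1cc(/C=N/NC(=O)Nc2ccc(Oc3ccnc(-c4nncn4CCN(C)C)c3)c(F)c2)ccc1O`, have been examined in a functional assay on U-87MG ATCC cells (Homo sapiens) for cytotoxicity, read by MTT assay, with a stated time of 72 h; a higher number here means a weaker inhibitor, a lower number a stronger inhibitor. In this assay compound 1 gives 2330 nM, and compound 2 gives 7650 nM. For compound 3 only a limit is known in this assay, > 100000 nM, so its position is the weakest end of the set, at the limit (the limit of > 100000 nM in this assay, at which 1 of the 3 values shown sits). The measured steps toward it are both large: an at least 42-fold higher number from compound 1 to compound 3 (1.63 log units; beyond the scatter) and an at least 13-fold higher number from compound 2 to compound 3 (1.11 log units; beyond the scatter), while a 3.3-fold higher number from compound 1 to compound 2 (0.52 log units; beyond the scatter) is more modest.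

Compound 4 `Cc1cc(/C=N/NC(=O)Nc2ccc(Oc3ccnc(-c4nncn4CCN(C)C)c3)c(F)c2)cc(C)c1O` differs from compound 3 by a single change: 4-hydroxy-3,5-dimethylphenyl in place of 4-hydroxy-3-methoxyphenyl on a carbon with a double bond to nitrogen. Among the measured compounds shown here, neither measured step concerns this kind of exchange; they show only that the aryl group on the carbon with a double bond to nitrogen governs the number strongly and that the 4-hydroxy-3-methoxyphenyl of compound 3 sits at the limit. Since compound 4 keeps the phenol of compound 3, it is expected to remain weak in this assay, with the step of an at least 1.6-fold lower number from compound 3 to compound 4 (0.22 log units; that floor lies within the scatter) estimated as small or none beyond the scatter. Compound 4 is therefore expected to give about 60000 nM, within 15000 nM to 100000 nM, with a real chance that only a limit is reported again.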

Compound 4, half-maximal inhibitory concentration: 7710 nM
The estimate for compound 4 lay 7.8-fold (0.89 log units) above the measured number; measured number outside the range, below it.
By their numbers in this assay, from the lowest: compound 1; then compounds 2 and 4 (each within the scatter of the next). At a limit, above all of these: compound 3.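

In this assay, the value for compound 3 is a limit and not a number: the limit of > 100000 nM in this assay, at which 1 of the 4 values shown sits. Putting 4-hydroxy-3,5-dimethylphenyl in place of 4-hydroxy-3-methoxyphenyl on a carbon with a double bond to nitrogen keeps the hydroxyl yet brings the compound into the measured range (an at least 12-fold lower number from compound 3 to compound 4 (1.11 log units; beyond the scatter)), so a hydroxyl on this aryl group does not by itself leave a compound at the limit. Among the compounds shown here, compound 4 cannot be told apart from the trimethoxyphenyl compound (a 1.0-fold higher number from compound 2 to compound 4 (0.00 log units; within the scatter)), and its modest gap to the dichlorophenyl compound (a 3.3-fold higher number from compound 1 to compound 4 (0.52 log units; beyond the scatter)) matches the one already seen for compound 2, so this position tolerates quite different aryl groups, with compound 3 the one that goes against this.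

The compounds shown do not separate the part played by the two methyl groups from that played by the loss of the methoxy group, and they give no measured property that would explain the step. They also leave open whether ethyl or chlorine in place of those methyl groups, or an amine in place of the hydroxyl, would keep the number where compound 4 stands.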